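A few compounds are considered here, and "the series" means these few. Any claim that something is new, unique, unknown or untested is made for them only; others in the source may bear on it.

Measured so far in an assay on RBL-1 cells for inhibition of Polyunsaturated fatty acid 5-lipoxygenase (Rattus norvegicus); on this read-out lower numbers stand for stronger inhibition and higher numbers for weaker inhibition:
- compound 1, `COc1ccc(C(=O)/C=C/c2ccc(O)c(OC)c2)cc1`: 12000 nM
- compound 2, `O=C(/C=C/c1ccc(O)c(O)c1)c1ccc([N+](=O)[O-])cc1`: 23 nM

Among the measured compounds shown here, compound 2 holds the lowest number of the two; compound 1 sits far higher, well beyond the scatter, but the two differ in more than one place, so no single step is drawn from them.

Compound 3, `CC(C)Oc1ccc(C(=O)/C=C/c2ccc(O)c(O)c2)cc1`, is the next candidate. Against compound 2 the change is isopropoxy in place of nitro on an aromatic carbon. For the measured compounds named here, no measured pair covers this exchange, so the expectation rests only on compound 2 and its value 23 nM in this assay. A rise of moderate size, beyond the scatter, is expected, a 4.3-fold higher number from compound 2 to compound 3 (0.64 log units; beyond the scatter). Compound 3 is estimated at 100 nM, with a range from 25 nM to 500 nM.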

Compound 3, half-maximal inhibitory concentration: 41 nM
Compound 3: the middle estimate sits 2.4-fold (0.39 log units) above what was measured, and the stated range covers the measured number.
By their numbers in this assay, from the lowest: compounds 2 and 3 (each within the scatter of the next); then compound 1.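

In this assay, isopropoxy in place of nitro on this aromatic carbon, para to a large group, gives a 1.8-fold higher number from compound 2 to compound 3 (0.25 log units; within the scatter), a step within the scatter. The place therefore holds either group at a comparable number, although the two share only oxygen among their heavy atoms and nitro alone brings nitrogen and a double bond. Nothing available explains this equivalence.

From the compounds shown here alone, whether an amine, a carboxylic acid or a longer chain on the oxygen would fit here stays open. Compound 1 differs from the others in more than one place, so the origin of its much higher number also stays unassigned.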